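The source may hold more compounds than are shown below. What is called first, only, known or untested is meant among the compounds shown, and "the series" means these compounds.

Measured so far in an ADME assay on liver for metabolic stability, with Liver microsome (Rattus norvegicus) as the target, read by LC-MS, using microsomes, with a stated time of 5 h; a higher number here means faster removal of the compound, a lower number slower removal:
compound 1 `C[C@]1(O)C[C@@](c2cccc(C(F)(F)F)c2)([C@H](O)c2ccccn2)C1`: 317 mL/min/kg
compound 2 `C[C@]1(O)C[C@](c2cccc(C(F)(F)F)c2)([C@H](O)c2ccccn2)C1`: 66.7 mL/min/kg

Compound 1 stands highest of the two numbers, with compound 2 nearest; the step of a 4.8-fold lower number from compound 1 to compound 2 (0.68 log units; beyond the scatter) is accounted for only by the fact that compounds 1 and 2 differ only in the configuration as drawn. Compound 3 `O[C@H](c1ccccn1)[C@]1(c2cccc(C(F)(F)F)c2)C[C@@H](O)C1` differs from compound 1 by hydrogen in place of methyl on a saturated ring carbon. Within the data shown here, no measured step changes a methyl; the one step at hand concerns configuration alone and is of modest size, so it gives no direct guide here. For compound 3 the change is expected to carry no step beyond the scatter, estimated at a 1.3-fold lower number from compound 1 to compound 3 (0.10 log units; within the scatter). Compound 3 is therefore expected near 250 mL/min/kg, within 100 mL/min/kg to 600 mL/min/kg.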

Compound 3, clearance: 100 mL/min/kg
The estimate for compound 3 lay 2.5-fold (0.40 log units) above the measured number; the range from low to high includes it.
By their numbers in this assay, from the lowest: compounds 2 and 3 (each within the scatter of the next); then compound 1.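

In this assay, the ring carbon two ring bonds from the atom bearing the hydroxy(pyridin-2-yl)methyl group responds to a single-atom change, with a 3.2-fold lower number from compound 1 to compound 3 (0.50 log units; beyond the scatter) on hydrogen replacing methyl. Among these compounds, this is the first step that involves a change of atoms, as the earlier step involved none: the fact that compounds 1 and 2 differ only in the configuration as drawn. The data give no cause for the new step, only its size and direction.

Open, on these data alone, is whether the same replacement gives a similar step in the configuration of compound 2. Also open, as far as these compounds go, is how an ethyl group, an amine or a fluorine on this ring carbon would compare.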